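The source may report more compounds than this note shows. Statements on the series, on what has been measured and on what is new or still open speak of the compounds shown alone.

Measured compounds:
- Compound 1 `O=c1cc(-c2ccccc2)oc2cc(O)c(OCCCN3CCCC3)c(O)c12` gives the assay limit > 100000 nM.
- Compound 2 `COc1cc2oc(-c3ccccc3)cc(=O)c2c(O)c1OCCCN1CCCC1` gives 6500 nM.
- Compound 3 `O=c1cc(-c2ccccc2)oc2cc(OCc3ccccc3)c(OCCCCN3CCCC3)c(O)c12` gives 3200 nM.

All three were tested in a functional assay on BCG823 cells (Homo sapiens) for antiproliferative activity, read by MTT assay, with a stated time of 48 h; on this read-out higher numbers stand for weaker inhibition and lower numbers for stronger inhibition. For compound 1 the value is a limit of the assay and not a number. Among the two real numbers compound 2 stands highest, and the nearest value, that of compound 3, is lower by a gap beyond the usual scatter. Among the compounds with values here, the one step between compounds that differ in a single place is an at least 15-fold lower number from compound 1 to compound 2 (1.18 log units; beyond the scatter), the change being methyl in place of hydrogen on an oxygen on an aromatic ring; compound 1 sits at the assay limit (the limit of > 100000 nM in this assay, at which 1 of the 3 values shown sits), so its true size is not fully known.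

Compound 4 `COc1cc2oc(-c3ccccc3)cc(=O)c2c(O)c1OCCCN1CCCCC1` is the next compound to consider. It differs from compound 2 in this way: piperidin-1-yl in place of pyrrolidin-1-yl on a saturated chain carbon, three bonds along the chain from an oxygen on an aromatic ring. None of the measured steps touches the ring on the chain end; the only step shown concerns the methyl on oxygen. There is therefore no basis for expecting a step in this assay beyond the usual scatter, in either direction. The estimated change is a 1.1-fold lower number from compound 2 to compound 4 (0.03 log units; within the scatter). Compound 4 is expected to give about 6000 nM, with a likely range from 2500 nM to 15000 nM.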

Compound 4, half-maximal inhibitory concentration: 25300 nM
Compound 4: middle estimate off by 4.2-fold (0.62 log units), on the low side, and the stated range ends below it.
By their numbers in this assay, from the lowest: compound 3; then compound 2; then compound 4. At a limit, above all of these: compound 1.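

The ring at the end of the chain turns out to matter in this assay: replacing pyrrolidin-1-yl with piperidin-1-yl comes with a 3.9-fold higher number from compound 2 to compound 4 (0.59 log units; beyond the scatter), so inhibition is weaker with the larger ring. Within the data shown here, the only earlier single-place step concerned the methyl on an oxygen on the aromatic ring, so this is the first sign that the far end of the chain also influences the read-out, even though the change from 3-(pyrrolidin-1-yl)propyl to 3-(piperidin-1-yl)propyl adds just one ring carbon and leaves the counted donors, acceptors and net charge the same. Nothing measured here explains why these two rings differ.

On these data alone, what a morpholin-4-yl or a dimethylamino group would give at the same chain end remains open, so two rings cannot show whether the trend with ring size goes any further. As far as these compounds go, it is also open whether the same swap would carry a step of similar size on a longer chain, or on a core with a hydroxyl in place of the methoxy group.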